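A Halogen Swap at the Limit of a Cytotoxicity Test

The source may hold more compounds than are shown below. What is called first, only, known or untested is meant among the compounds shown, and "the series" means these compounds.

Of the compounds shown here, three sharing one core have been read in an ADME assay on 2209-23 cells (Homo sapiens) for cytotoxicity, read by WST assay and thymidine incorporation; on this read-out higher numbers stand for lower toxicity in this test and lower numbers for higher toxicity in this test. Compound 1 `CC(C)(C)[C@H]1C(O)=C(C2=CS(=O)(=O)c3cc(F)ccc3N2)C(=O)N1Cc1ccc(F)cc1` gives > 50000 nM, which is a limit of the assay and not a number. Compound 3 `CC(C)(C)[C@H]1C(O)=C(C2=CS(=O)(=O)c3cc([N+](=O)[O-])ccc3N2)C(=O)N1Cc1ccc(F)cc1` gives > 50000 nM, also a limit. Compound 2 `CC(C)(C)[C@H]1C(O)=C(C2=CS(=O)(=O)c3cc(NS(C)(=O)=O)ccc3N2)C(=O)N1Cc1ccc(F)cc1F` gives > 50000 nM, again a limit. Together they form (the limit of > 50000 nM in this assay, at which 3 of the 3 values shown sit).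

Among the measured compounds shown here, the only measured step, a step that the two limits leave unreadable from compound 1 to compound 3, has nitro in place of fluoro on an aromatic carbon, and its size cannot be read. Compound 4 `CC(C)(C)[C@H]1C(O)=C(C2=CS(=O)(=O)c3cc(NS(C)(=O)=O)ccc3N2)C(=O)N1Cc1ccc(F)c(Cl)c1` departs from compound 2 in a different way, with 3-chloro-4-fluorophenyl in place of 2,4-difluorophenyl on a saturated chain carbon bound to an amide-type nitrogen in a ring. For the measured compounds named here, no measured step covers this change, so the expectation rests on the limit shared by all three compounds in this assay. The expected step, a number no higher from compound 2 to compound 4 (the limit leaves the size open), is estimated to stay within the scatter, in neither direction. The estimate for compound 4 is 50000 nM, with an expected range of 20000 nM to 100000 nM.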

Compound 4, half-maximal cytotoxic concentration: > 50000 nM
Compound 4 was reported as a limit (the forecaster's own chance of this, stated with the estimate: 85%); the middle value sits exactly at the limit.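

Compound 2 and compound 4 both stand at a limit in this assay, so the step between them cannot be read. The compounds shown leave open the concentration at which any of them would become cytotoxic, as all share one limit: the limit of > 50000 nM in this assay, at which 4 of the 4 values shown sit.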